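Aryl Ether Carbamates Against Zeta-Carotene Desaturase: Methoxy After Cyano

This account rests on a few compounds, and the source may have more. Where it says the series, first, only, none or still open, it means among the compounds named here.

Compound 1, `CCC(COc1cccc(Cl)c1)OC(=O)NCc1ccccc1`: > 100000 nM
Compound 2, `CCC(COc1ccc(Cl)cc1)OC(=O)NCc1ccccc1`: > 100000 nM
Compound 3, `CCC(COc1cccc(C#N)c1)OC(=O)NCc1ccccc1`: > 100000 nM

Of the compounds shown here, three have so far been tested in an assay for inhibition of zeta-carotene desaturase, chloroplastic/chromoplastic (Capsicum annuum), using a Dixon plot, with a stated time of 8 h (on this read-out lower numbers stand for stronger inhibition and higher numbers for weaker inhibition), and none of them returned a number. For compound 1 the value > 100000 nM is a limit of the assay, not a measurement. Compound 2 likewise stands at a limit with > 100000 nM. Compound 3 also sits at a limit, > 100000 nM. Because of the limit of > 100000 nM in this assay, at which 3 of the 3 values shown sit, the three steps among these compounds cannot be read at all: a step that the two limits leave unreadable from compound 1 to compound 2, a step that the two limits leave unreadable from compound 1 to compound 3 and a step that the two limits leave unreadable from compound 2 to compound 3. Compound 3 therefore stands exactly where compound 1 and compound 2 stand, at the edge of what the assay can report.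

Compound 4, `CCC(COc1cccc(OC)c1)OC(=O)NCc1ccccc1`, differs from compound 3 by methoxy in place of cyano on an aromatic carbon. The measured steps that bear on this change are the exchanges of the group on the same ring among compounds 1, 2 and 3, and every one of them is unreadable, so they offer neither a direction nor a size. With all tested compounds at the limit, compound 4 is expected to stay at the limit too, so the expected step that the limit leaves unreadable from compound 3 to compound 4 is none beyond the scatter. The estimate for compound 4 in this assay is 150000 nM, with a range from 50000 nM to 1000000 nM.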

Compound 4, half-maximal inhibitory concentration: > 100000 nM
Compound 4: a limit, no number; the forecaster's own chance of this, stated with the estimate: 85%; the middle value does not contradict the limit.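

In this assay compound 4 gives > 100000 nM, a limit of the assay and not a number. The steps joining compound 4 to compound 1, compound 2 and compound 3 cannot be read because all four compounds share one limit: the limit of > 100000 nM in this assay, at which 4 of the 4 values shown sit.

The compounds shown leave open how strongly any of them inhibits the enzyme, and whether exchanging the group on the ring changes that strength at all.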